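The source may report more compounds than this note shows. Statements on the series, on what has been measured and on what is new or still open speak of the compounds shown alone.

Series measured in a functional assay on HepG2 cells for inhibition of squalene monooxygenase (Homo sapiens); a lower number here means a stronger inhibitor, a higher number a weaker inhibitor:

Compound 1 `CCN(C/C=C/C#CC(C)(C)C)Cc1cccc(OCCNS(=O)(=O)c2cccs2)c1` gives 450 nM.
Compound 2 `CCN(C/C=C/C#CC(C)(C)C)Cc1cccc(OCCN(C)S(=O)(=O)c2ccsc2)c1` gives 250 nM.
Compound 3 `CCN(C/C=C/C#CC(C)(C)C)Cc1cccc(OCCN(C)S(=O)(=O)c2nccs2)c1` gives 170 nM.

Compound 3 holds the lowest of the three numbers. Its separation from compound 1 is a 2.6-fold lower number from compound 1 to compound 3 (0.42 log units; beyond the scatter), whereas a 1.5-fold lower number from compound 2 to compound 3 (0.17 log units; within the scatter) and a 1.8-fold lower number from compound 1 to compound 2 (0.26 log units; within the scatter) both fall inside the usual scatter, so compound 2 and compound 3 cannot be ranked against each other.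

Compound 4 `CCN(C/C=C/C#CC(C)(C)C)Cc1cccc(OCCN(C)S(=O)(=O)c2cc(-c3ccsc3)cs2)c1` is the next member. Relative to compound 3 the change is 4-(thiophen-3-yl)thiophen-2-yl in place of 1,3-thiazol-2-yl on a sulfonyl sulfur.

For the measured compounds named here, the only measured step that alters the group on the sulfonyl sulfur alone is a 1.5-fold lower number from compound 2 to compound 3 (0.17 log units; within the scatter), and it stays within the scatter. The steps from compound 1 change the ring together with methylation of the sulfonamide nitrogen, so they bear less directly on this step. Going by the values given here, no measured step shows that the ring on the sulfonyl sulfur moves the number far, although no earlier compound carries a second ring there, so the comparison is a loose one. The expected step in this assay is therefore a 1.2-fold higher number from compound 3 to compound 4 (0.07 log units; within the scatter), with no confident direction beyond the scatter. Compound 4 is estimated at 200 nM, within 70 nM to 600 nM.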

Compound 4, half-maximal inhibitory concentration: 90 nM
Estimate against measurement, compound 4: 2.2-fold (0.35 log units) above, and the stated range covers the measured number.
By their numbers in this assay, from the lowest: compounds 4, 3, 2 and 1 (each within the scatter of the next, the first and the last beyond it).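

In this assay, the group on the sulfonyl sulfur can grow from 1,3-thiazol-2-yl to 4-(thiophen-3-yl)thiophen-2-yl, with a 1.9-fold lower number from compound 3 to compound 4 (0.28 log units; within the scatter) remaining a step that cannot separate the two compounds. For the compounds shown here, measured against thiophen-3-yl, the same two-ring group gives a 2.8-fold lower number from compound 2 to compound 4 (0.44 log units; beyond the scatter) and is the first change at this position alone to clear the scatter, so this place can move the number modestly. Nothing available explains this step.

Still open, as far as these compounds go, is whether the second ring matters as a thiophene or simply as a second aromatic ring, which a phenyl or pyridinyl group in place of the thiophen-3-yl on the thiophen-2-yl ring could test. Going by these compounds alone, the effect of the sulfonamide methyl also remains unseparated from that of the ring, as the only compound carrying the amide hydrogen also carries a different ring.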